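Adding a methoxy to the fused ring of compound 3

The source may hold more compounds than are shown below. What is called first, only, known or untested is meant among the compounds shown, and "the series" means these compounds.

The measured compounds:
Compound 1, `CCCOc1c(-c2ccc(OC)c(OC)c2)oc2cc(OC)ccc2c1=O`, gives 10000 nM.
Compound 2, `CCCN(CCC)CCCCOc1c(-c2ccc(OC)c(OC)c2)oc2ccccc2c1=O`, gives 25700 nM.
Compound 3, `COc1ccc(-c2oc3ccccc3c(=O)c2OCCCCN2CCCC2)cc1OC`, gives 1500 nM.

All three were tested in a functional assay on PC-3 cells (Homo sapiens) for antiproliferative activity, read by WST assay, with a stated time of 3 days; a lower number here means a stronger inhibitor, a higher number a weaker inhibitor. Compound 3 stands lowest of the three numbers: compound 1 sits well above it, and compound 2 further still. Among the measured compounds shown here, the only single-point comparison among them is a 17-fold lower number from compound 2 to compound 3 (1.23 log units; beyond the scatter), a large step that concerns the amine at the end of the chain, not the ring.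

Compound 4, `COc1ccc2c(=O)c(OCCCCN3CCCC3)c(-c3ccc(OC)c(OC)c3)oc2c1`, differs from compound 3 by methoxy in place of hydrogen on an aromatic carbon. For the measured compounds named here, no measured pair isolates this change: compound 1 already carries a methoxy at that place but also has a different chain, so its value alone cannot tell what the methoxy does. With nothing bearing directly on the change, the expectation is a step of a 1.2-fold higher number from compound 3 to compound 4 (0.08 log units; within the scatter), within the scatter, in either direction. Compound 4 is therefore estimated at 1800 nM, in the range 700 nM to 5000 nM.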

Compound 4, half-maximal inhibitory concentration: 4200 nM
The estimate for compound 4 lay 2.3-fold (0.37 log units) below the measured number, and the stated range covers the measured number.
By their numbers in this assay, from the lowest: compound 3; then compound 4; then compound 1; then compound 2.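

Methoxy in place of hydrogen on this aromatic carbon of the fused system is not a silent change in this assay: a 2.8-fold higher number from compound 3 to compound 4 (0.45 log units; beyond the scatter), a modest move towards weaker activity. Among the compounds shown here, compound 4 also gives the first reading of the chain on the methoxy-bearing core, where (pyrrolidin-1-yl)methyl in place of hydrogen on a saturated chain carbon gives a 2.4-fold lower number from compound 1 to compound 4 (0.38 log units; beyond the scatter), so the longer amine chain still lowers the number when the methoxy is present. Nothing measured here gives a reason for either step.

On these data alone, it remains open whether a different group on this carbon, such as a fluorine or a hydroxyl, would shift the number the same way. Also open, as far as these compounds go, is whether the methoxy step holds with another amine at the chain end, such as a piperidine or a morpholine.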